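Iodo in place of fluoro at the limit

The compounds below may be only part of what the source reports. "The series", "measured", "known", "first", "only" and "open" are said of these compounds alone.

Measured so far in a functional assay on MT4 cells (Homo sapiens), read by MTT assay (a higher number here means that more compound is tolerated, a lower number that less compound is tolerated), as follows:
Compound 1 (`C#C[C@]1(CO)O[C@@H](n2ccc(=O)[nH]c2=O)C[C@@H]1O`) gives > 100000 nM (a limit)
Compound 2 (`C#C[C@]1(CO)O[C@@H](n2cc(F)c(=O)[nH]c2=O)C[C@@H]1O`) gives 3400 nM (a number)
Compound 3 (`C#C[C@]1(CO)O[C@@H](n2cc(F)c(N)nc2=O)C[C@@H]1O`) gives > 100000 nM (a limit)

Compound 3 has no number of its own, and its reading sits at the limit of > 100000 nM in this assay, at which 2 of the 3 values shown sit (shared with compound 1). Compound 4 (`C#C[C@]1(CO)O[C@@H](n2cc(I)c(N)nc2=O)C[C@@H]1O`) differs from it by one change, iodo in place of fluoro on an aromatic carbon. Going by the values given here, only one measured step involves a halogen, namely an at least 29-fold lower number from compound 1 to compound 2 (1.46 log units; beyond the scatter) (fluoro in place of hydrogen on an aromatic carbon). That step is large, but it is a different exchange and gives only a weak guide here. Compound 2 gives 3400 nM as a true number. Compound 3 also carries fluoro and still reads only as a limit. A modest move towards a lower number is therefore possible, though a reading at the limit is at least as likely. The estimated at least 1.2-fold lower number from compound 3 to compound 4 (0.09 log units; that floor lies within the scatter) is accordingly small. Compound 4 is expected near 80000 nM in this assay with an estimated range of 20000 nM to 200000 nM as its span.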

Compound 4, half-maximal cytotoxic concentration: > 100000 nM
Compound 4 gave a limit, no number; the forecaster's own chance of this, stated with the estimate: 60%; middle value at least 1.2-fold (0.09 log units) away from the limit.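

Compound 3 and compound 4 both read only as limits in this assay, so no step between them can be read, and both stand at the same limit: the limit of > 100000 nM in this assay, at which 3 of the 4 values shown sit.

The compounds shown leave open whether iodo in place of fluoro on an aromatic carbon shifts the tolerated concentration at all.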